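Selenium-bearing fused bicyclics: cytotoxicity on colon cells

This account rests on a few compounds, and the source may have more. Where it says the series, first, only, none or still open, it means among the compounds named here.

Measured so far:
- compound 1 `C[Se]c1nc(N)c2ccccc2n1`: > 100000 nM, a limit
- compound 2 `C[Se]c1nc([Se]C)c2cccnc2n1`: "not determined" (no result reported)
- compound 3 `[SeH]c1nc([SeH])c2ccccc2n1`: 87900 nM

Among the compounds with values here, in a functional assay on HT-29 cells (Homo sapiens) for cytotoxicity, read by MTT assay, with a stated time of 72 h (on this read-out lower numbers stand for higher toxicity in this test and higher numbers for lower toxicity in this test), compound 3 gives 87900 nM, the only plain number so far. For compound 1 the assay reports only a limit, > 100000 nM, and for compound 2 no result is given. Compound 4 `Nc1nc([SeH])nc2ccccc12` differs from compound 3 by one nitrogen atom in place of one selenium atom, on an aromatic carbon. Within the data shown here, no measured step between two compounds is available to size this change. Given the limit of > 100000 nM in this assay, at which 1 of the 3 values shown sits, for the amino-bearing compound 1, the step to compound 4 is expected to run toward higher numbers in this assay, with a real chance of another limit. Compound 4 is estimated at 150000 nM, expected between 60000 nM and 400000 nM. That estimate corresponds to an expected step of a 1.7-fold higher number from compound 3 to compound 4 (0.23 log units; within the scatter).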

Compound 4, concentration lethal to 50% of the cells: > 100000 nM
Compound 4 ended at the assay's limit (the forecaster's own chance of this, stated with the estimate: 60%); the middle value does not contradict the limit.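

In this assay compound 4 gives > 100000 nM, which is a limit and not a number. Amino in place of one selenium atom on this aromatic carbon gives an at least 1.1-fold higher number from compound 3 to compound 4 (0.05 log units; that floor lies within the scatter), the first step sized at this position, though only as a floor. The step between compound 1 and compound 4 cannot be read, and both amino-bearing compounds end at the same limit: the limit of > 100000 nM in this assay, at which 2 of the 4 values shown sit.

Going by these compounds, how far compound 4 lies past its limit remains open. Also open, on these data alone, is whether a dimethylamino group or a carboxylic acid on this aromatic carbon would give a plain number in this assay.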